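The compounds below may be only part of what the source reports. "The series", "measured", "known", "first", "only" and "open" are said of these compounds alone.

Compound 1 `CCCN(CCC)c1ccc(C)c2nc(-c3c(OC)cc(COC)cc3OC)c(C)cc12` gives 88 nM in an assay on HEK293 cells for displacement of a labelled ligand from corticotropin-releasing factor receptor 1 (Homo sapiens), with a stated time of 2 h; a lower number here means a stronger inhibitor, a higher number a weaker inhibitor.
Compound 2 `COCc1cc(OC)c(-c2nc3c(C)ccc(N(CC4CC4)CC4CC4)c3cc2C)c(OC)c1` gives 88 nM in this assay.
Compound 3 `CCC(CC)Nc1ccc(C)c2nc(-c3c(OC)cc(COC)cc3OC)c(C)cc12` reaches only a limit in this assay, > 1000 nM.

Compound 1 stands level with compound 2, as no change at the digits printed from compound 1 to compound 2 (within the scatter) shows. The value of compound 3 is a limit (the limit of > 1000 nM in this assay, at which 1 of the 3 values shown sits), and the step of an at least 11-fold higher number from compound 1 to compound 3 (1.05 log units; beyond the scatter) is large, as is an at least 11-fold higher number from compound 2 to compound 3 (1.05 log units; beyond the scatter). Compound 4 `CCCN(CCC)c1ccc(CC)c2nc(-c3c(OC)cc(COC)cc3OC)c(C)cc12` differs from compound 1 by methyl in place of hydrogen on a saturated chain carbon bound to an aromatic carbon. Neither measured step touches this place; all three concern the amino group, so they give no direct guide. In the absence of such a step, compound 4 is expected to stay close to compound 1, with a 1.1-fold higher number from compound 1 to compound 4 (0.06 log units; within the scatter) estimated as lying within the scatter. Compound 4 is therefore estimated at 100 nM, in the range 40 nM to 300 nM.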

Compound 4, half-maximal inhibitory concentration: 115 nM
Compound 4: the middle estimate sits 1.2-fold (0.06 log units) below what was measured; low and high end bracket the measured number.
By their numbers in this assay, from the lowest: compounds 1, 2 and 4 (each within the scatter of the next). At a limit, above all of these: compound 3.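

Within the data shown here, at this position, which none of the earlier steps on the amino group touched, this assay gives a 1.3-fold higher number from compound 1 to compound 4 (0.12 log units; within the scatter), so the methyl to ethyl change leaves compound 4 and compound 1 indistinguishable. Among these compounds, this is the first sign that the shared core accepts a longer chain at this place without a step beyond the scatter. Nothing shown offers a reason for this result.

As far as these compounds go, whether a propyl chain, a methoxy group or an amine would fare the same at this place remains open. So does whether ethyl behaves alike when bis(cyclopropylmethyl)amino replaces dipropylamino.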